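Dimethylamino for methyl on the core of compound 1

The source may report more compounds than this note shows. Statements on the series, on what has been measured and on what is new or still open speak of the compounds shown alone.

Measured so far in an ADME assay on BJ cells (Homo sapiens), read by MTT assay, with a stated time of 72 h; a higher number here means a weaker inhibitor, a lower number a stronger inhibitor:
compound 1, `Cc1ncnc2c1c(-c1cccs1)cn2[C@@H]1O[C@H](CO)[C@@H](O)[C@H]1O`, > 100000 nM
compound 2, `Cc1ncnc2c1c(-c1cc3ccccc3o1)cn2[C@@H]1O[C@H](CO)[C@@H](O)[C@H]1O`, 93900 nM
compound 3, `Cc1ncnc2c1c(-c1ccsc1)cn2[C@@H]1O[C@H](CO)[C@@H](O)[C@H]1O`, 96900 nM

Going by the values given here, compound 1 stands at a limit of this assay, not at a number; it is the one value of the three sitting at the limit of > 100000 nM in this assay, at which 1 of the 3 values shown sits. Compound 2 and compound 3 give numbers close to that limit. The steps of an at least 1.0-fold lower number from compound 1 to compound 2 (0.02 log units; that floor lies within the scatter) and an at least 1.0-fold lower number from compound 1 to compound 3 (0.01 log units; that floor lies within the scatter) are floors that lie within the scatter, and the step of a 1.0-fold higher number from compound 2 to compound 3 (0.01 log units; within the scatter) is within the scatter as well; all three concern the aryl group on the core and none touches the position changed here.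

Compound 4 is `CN(C)c1ncnc2c1c(-c1cccs1)cn2[C@@H]1O[C@H](CO)[C@@H](O)[C@H]1O`. It differs from compound 1 in that (dimethylamino in place of methyl on an aromatic carbon). Among the compounds with values here, no measured step bears on this change, so there is no basis for a shift in either direction beyond the scatter. The expected step is therefore a number no higher from compound 1 to compound 4 (the limit leaves the size open). Compound 4 is accordingly estimated at 100000 nM, with a range from 40000 nM to 300000 nM, and a substantial chance that this assay again reports only a limit for it.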

Compound 4, half-maximal inhibitory concentration: > 100000 nM
Compound 4 gave a limit, no number; the forecaster's own chance of this, stated with the estimate: 55%; the middle value lies on the limit itself.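

Compound 1 and compound 4 both stand at a limit of the assay and not at a number, so the step between them cannot be read: the limit of > 100000 nM in this assay, at which 2 of the 4 values shown sit.

The compounds shown leave open whether dimethylamino in place of methyl on an aromatic carbon shifts the number in this assay in either direction, and by how much.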